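Switching the benzyl aryl group of compound 3

The source may report more compounds than this note shows. Statements on the series, on what has been measured and on what is new or still open speak of the compounds shown alone.

Three sulfonamides sharing one core have been measured. In a functional assay on MCF7 cells (Homo sapiens) for inhibition, read by MTT assay, with a stated time of 72 h (on this read-out higher numbers stand for weaker inhibition of growth and lower numbers for stronger inhibition of growth), compound 1 `O=S(=O)(NCCNCc1cccc2ccccc12)c1cc(C(F)(F)F)cc(C(F)(F)F)c1` gives 18000 nM, compound 2 `O=S(=O)(NCCCCNCc1ccc(Br)cc1)c1cc(C(F)(F)F)cc(C(F)(F)F)c1` gives 1500 nM, and compound 3 `O=S(=O)(NCCCNCc1ccc(Cl)c(Cl)c1)c1cc(C(F)(F)F)cc(C(F)(F)F)c1` gives 2400 nM. Compound 3 therefore holds the second highest number of the three, closest to compound 2 and far from compound 1. Within the data shown here, the one step measured between single-point neighbours, a 1.6-fold higher number from compound 2 to compound 3 (0.20 log units; within the scatter), changed the aryl end of the chain and left the number essentially where it was.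

Compound 4 `O=S(=O)(NCCCNCc1ccc(C(F)(F)F)cc1)c1cc(C(F)(F)F)cc(C(F)(F)F)c1` differs from compound 3 only by 4-(trifluoromethyl)phenyl in place of 3,4-dichlorophenyl on a saturated chain carbon bound to an amine nitrogen. Among the measured compounds shown here, no measured pair shows this exact exchange, so the only guide is the step from compound 2 to compound 3, where a different aryl change produced nothing beyond the scatter. On that basis the step from compound 3 to compound 4 is expected to be small, a 1.0-fold higher number from compound 3 to compound 4 (0.02 log units; within the scatter), with no clear direction. Compound 4 is accordingly estimated at 2500 nM in this assay, within a range from 1000 nM to 6500 nM.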

Compound 4, concentration for 50% growth inhibition: 1400 nM
The estimate for compound 4 lay 1.8-fold (0.25 log units) above the measured number, and the stated range covers the measured number.
By their numbers in this assay, from the lowest: compounds 4, 2 and 3 (each within the scatter of the next); then compound 1.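

In this assay, a 1.7-fold lower number from compound 3 to compound 4 (0.23 log units; within the scatter) shows that this position, on a saturated chain carbon bound to an amine nitrogen, takes 4-(trifluoromethyl)phenyl, with 10 heavy atoms, in place of 3,4-dichlorophenyl, with 8, without a shift that stands clear of the scatter. Unlike the step from compound 2 to compound 3, this exchange leaves the chain untouched, so it tests the aryl group alone. No evidence bearing on this result is available.

The compounds shown leave open whether the number would hold with a pyridine ring or a cyclohexyl group in place of the aryl ring, or with a carboxylic acid on that ring. Compound 1 differs from compound 4 in more than one place, so its much higher number cannot be tied to a single change.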